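Amide Variation on the Ring Carbon of the Shared Core

This account rests on a few compounds, and the source may have more. Where it says the series, first, only, none or still open, it means among the compounds named here.

Measured so far in a functional assay for inhibition of nuclear factor NF-kappa-B complex (Homo sapiens); on this read-out higher numbers stand for weaker inhibition and lower numbers for stronger inhibition:
Compound 1 `CCOCC1=Cc2ccc(OC)cc2OC1c1cc(OC)c(OC)c(OC)c1` gives 21300 nM.
Compound 2 `COc1ccc2c(c1)OC(c1cc(OC)c(OC)c(OC)c1)C(C(=O)O)=C2` gives only the limit of this assay, > 50000 nM.
Compound 3 `COc1ccc2c(c1)OC(c1cc(OC)c(OC)c(OC)c1)C(C(=O)N(C)C)=C2` gives only the limit of this assay, > 50000 nM.

Compound 3 therefore stands at the limit, not at a number, and the same holds for one further value: the limit of > 50000 nM in this assay, at which 2 of the 3 values shown sit. The step from the ethoxymethyl analogue to the acid reads an at least 2.3-fold higher number from compound 1 to compound 2 (0.37 log units; beyond the scatter), and that to the dimethylamide reads an at least 2.3-fold higher number from compound 1 to compound 3 (0.37 log units; beyond the scatter). Between the two carbonyl compounds the step is a step that the two limits leave unreadable from compound 2 to compound 3.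

Compound 4 `CCNC(=O)C1=Cc2ccc(OC)cc2OC1c1cc(OC)c(OC)c(OC)c1` differs from compound 3 by ethylamino in place of dimethylamino on a carbonyl carbon. Among the measured compounds shown here, the only measured step at the same carbonyl carbon is a step that the two limits leave unreadable from compound 2 to compound 3, which gives no size, and no measured step separates two amides. Both compounds bearing a carbonyl on the ring carbon sit at the limit, so the change is expected to give a step that the limit leaves unreadable from compound 3 to compound 4, a step not beyond the scatter. Compound 4 is thus expected near the limit, at about 60000 nM, within 20000 nM to 150000 nM.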

Compound 4, half-maximal inhibitory concentration: > 50000 nM
Compound 4: only a limit was reported; the forecaster's own chance of this, stated with the estimate: 70%; the middle value does not contradict the limit.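

In this assay compound 4 also gives only a limit, > 50000 nM. Ethylcarbamoyl in place of ethoxymethyl on the double-bonded ring carbon gives an at least 2.3-fold higher number from compound 1 to compound 4 (0.37 log units; beyond the scatter), so the amide hydrogen, absent from the dimethylamide, does not bring this series under the limit, and all three carbonyl groups tried at this position read weaker than the ethoxymethyl group. Among the compounds shown here, the steps among the three carbonyl compounds cannot be read, and the ethoxymethyl analogue remains the only compound here with a numerical value: the limit of > 50000 nM in this assay, at which 3 of the 4 values shown sit.

Going by these compounds, how the three carbonyl compounds rank against one another stays open. On these data alone, whether the ethoxymethyl value can be improved also stays open, and a hydroxymethyl, aminomethyl or longer propoxymethyl group on this ring carbon would address that.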